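Lipophilicity After a Ring Group Swap in Compound 3

This account rests on a few compounds, and the source may have more. Where it says the series, first, only, none or still open, it means among the compounds named here.

Measured in a physicochemical assay for lipophilicity, using the shake flask method, measured as octanol-water partition, at pH 7.4; on this read-out lower numbers stand for lower lipophilicity and higher numbers for higher lipophilicity:
- compound 1 `CC(C)n1cc(-c2ccnc3[nH]c(C4CCNCC4)cc23)ccc1=O`: -0.2
- compound 2 `CC(=O)N1CCC(c2cc3c(-c4ccc(=O)n(C(C)C)c4)ccnc3[nH]2)CC1`: 2.1
- compound 3 `CC(C)n1nc(-c2ccnc3[nH]c(C4CCN(CC(=O)N(C)C)CC4)cc23)ccc1=O`: 2

In this assay, compound 3 lies within the scatter of compound 2 and beyond the scatter above compound 1. The next compound, compound 4 `COc1cc(=O)n(C)cc1-c1ccnc2[nH]c(C3CCN(CC(=O)N(C)C)CC3)cc12`, differs from compound 3 in one place, on an aromatic carbon of the shared core: a group of 10 heavy atoms (7 carbon, 1 nitrogen, 2 oxygen; one six-membered aromatic ring with 1 hetero atom) in place of a group of 10 heavy atoms (7 carbon, 2 nitrogen, 1 oxygen; one six-membered aromatic ring with 2 hetero atoms), on an aromatic carbon. The amine nitrogen in the ring carries the same substituent in both compounds.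

Among the compounds with values here, the only measured step, a number 2.30 log units higher from compound 1 to compound 2 (beyond the scatter), concerns a change at that amine nitrogen, not at the place that changes here. It therefore gives no direct guide to size or direction. The expectation starts from compound 3 at 2 and leans cautiously downward, with a wide range. The step expected is a number 0.50 log units lower from compound 3 to compound 4 (beyond the scatter). For compound 4 the estimated value is 1.5, with an expected range from 0.9 to 2.1.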

Compound 4, distribution coefficient: 0.7
Estimate against measurement, compound 4: 0.80 log units above, outside the stated range (below it).
By their numbers in this assay, from the lowest: compound 1; then compound 4; then compounds 3 and 2 (each within the scatter of the next).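

In this assay, the aromatic carbon opposite the ring nitrogen turns out to be a place where a single change matters, with a step of a number 1.30 log units lower from compound 3 to compound 4 (beyond the scatter). The two groups match in their count of 10 heavy atoms, in hydrogen-bond donors and acceptors and in having no net charge, so a large step appears here even though those counts stay the same, and the earlier step concerned only the amine nitrogen in the ring. Nothing measured alongside these compounds offers an explanation for the size of this step.

The two groups differ in more than one feature, and the compounds shown do not separate the ring's hetero atom count from the other differences between them. On these data alone, it also remains open how this assay would read with an amine or a carboxylic acid on the ring at this position.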